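A few compounds are considered here, and "the series" means these few. Any claim that something is new, unique, unknown or untested is made for them only; others in the source may bear on it.

In an assay on HEK293 cells for inhibition of N-acylethanolamine-hydrolyzing acid amidase (Rattus norvegicus), read by LC-MS, with a stated time of 30 min (on this read-out higher numbers stand for weaker inhibition and lower numbers for stronger inhibition), three compounds have been measured so far. Compound 1 `O=C1OCCN1C(=O)c1ccc(Oc2ccc(O)cc2)cc1` gives > 20000 nM, which is a limit of the assay rather than a number (the limit of > 20000 nM in this assay, at which 1 of the 3 values shown sits). Compound 2 `CCC(CC)Oc1ccc(C(=O)N2CCOC2=O)cc1` gives 480 nM, and compound 3 `CCCCCCOc1ccc(C(=O)N2CCOC2=O)cc1` gives 640 nM. The step of an at least 41-fold lower number from compound 1 to compound 2 (1.61 log units; beyond the scatter) and the step of an at least 31-fold lower number from compound 1 to compound 3 (1.49 log units; beyond the scatter) are both large, whereas the step of a 1.3-fold higher number from compound 2 to compound 3 (0.12 log units; within the scatter) stays within the scatter. Compound 3 therefore stands alongside compound 2, the two numbers not being distinguishable from each other, while compound 1 is set apart only as a limit.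

Compound 4 `O=C1OCCN1C(=O)c1ccc(OC2CCOCC2)cc1` has not yet been measured. Its change from compound 3 is oxan-4-yl in place of hexyl on an oxygen on an aromatic ring. The measured steps touch this change only in part: the exchange of one chain for another changed little, and the two large steps both removed a 4-hydroxyphenyl ring from the same oxygen. None of them brings in a six-membered non-aromatic ring carrying one oxygen, so the expected step of a 2.3-fold higher number from compound 3 to compound 4 (0.37 log units; beyond the scatter) is a modest rise in the number, near the edge of the scatter. Compound 4 is accordingly estimated at 1500 nM, with a range from 500 nM to 5000 nM.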

Compound 4, half-maximal inhibitory concentration: 330 nM
For compound 4 the middle estimate is 4.5-fold (0.66 log units) above the measured one; the measured number lies below the stated range.
By their numbers in this assay, from the lowest: compounds 4, 2 and 3 (each within the scatter of the next). At a limit, above all of these: compound 1.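

Oxan-4-yl brings a six-membered non-aromatic ring and a hydrogen-bond acceptor onto the oxygen on the aromatic ring, yet in this assay it cannot be told apart from hexyl (a 1.9-fold lower number from compound 3 to compound 4 (0.29 log units; within the scatter)) or from pentan-3-yl (a 1.5-fold lower number from compound 2 to compound 4 (0.16 log units; within the scatter)). Among the groups shown, this position therefore accepts a ring with an oxygen in it as well as it accepts an open carbon chain, and compound 2, compound 3 and compound 4 form a single level with no order among them, while the gap to the 4-hydroxyphenyl compound holds for this new group too (an at least 60-fold lower number from compound 1 to compound 4 (1.78 log units; beyond the scatter)). Compound 1 stands at a limit of the assay and not at a number, so that step gives only a minimum size: the limit of > 20000 nM in this assay, at which 1 of the 4 values shown sits.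

A cyclohexyl group, the same ring with carbon in place of its oxygen, would show whether the ring oxygen counts at all, and a piperidin-4-yl group would put an amine in that place. A plain phenyl group would show whether the aromatic ring or its hydroxyl goes with the much higher value of compound 1.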